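Changing the carbonyl substituent: compound 3 to compound 4

The compounds below may be only part of what the source reports. "The series", "measured", "known", "first", "only" and "open" are said of these compounds alone.

Measured values in a functional assay on liver (Rattus norvegicus, strain Sprague-Dawley) for inhibition, with a stated time of 1 h; a lower number here means a stronger inhibitor, a higher number a weaker inhibitor
compound 1 `COc1ccc(C(=O)OCC2Oc3ccc([C@H]4Oc5cc(O)cc(O)c5C(=O)[C@@H]4O)cc3OC2c2ccc(O)c(OC)c2)cc1` gives 21000 nM
compound 2 `COc1cc(C2Oc3cc([C@H]4Oc5cc(O)cc(O)c5C(=O)[C@@H]4O)ccc3OC2COC(=O)c2cccc(Cl)c2)ccc1O` gives 14200 nM
compound 3 `COc1cc(C2Oc3cc([C@H]4Oc5cc(O)cc(O)c5C(=O)[C@@H]4O)ccc3OC2COC(=O)c2cc(N)cc([N+](=O)[O-])c2)ccc1O` gives 200 nM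

Compound 3 holds the lowest number of the three, and both steps to it are large (a 71-fold lower number from compound 2 to compound 3 (1.85 log units; beyond the scatter)) and (a 110-fold lower number from compound 1 to compound 3 (2.02 log units; beyond the scatter)). Compound 4 `COc1cc(C2Oc3cc([C@H]4Oc5cc(O)cc(O)c5C(=O)[C@@H]4O)ccc3OC2COC(=O)/C=C/c2ccc(Cl)cc2)ccc1O` differs from it as follows (2-(4-chlorophenyl)ethenyl in place of 3-amino-5-nitrophenyl on a carbonyl carbon): 2-(4-chlorophenyl)ethenyl in place of 3-amino-5-nitrophenyl on a carbonyl carbon. The measured steps at this same place are the ones that bear on the change. Exchanging the group of compound 1 for that of compound 2 gave only a step within the scatter (a 1.5-fold lower number from compound 1 to compound 2 (0.17 log units; within the scatter)), whereas both steps to the 3-amino-5-nitrophenyl group were large. Going by the values given here, that group is lost in compound 4, so a large step back to a higher number is expected in this assay even though no measured compound carries the 2-(4-chlorophenyl)ethenyl group. The expected step runs upward (a 30-fold higher number from compound 3 to compound 4 (1.48 log units; beyond the scatter)). For compound 4 the estimate is 6000 nM (expected range 1000 nM to 30000 nM).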

Compound 4, half-maximal inhibitory concentration: 12000 nM
Compound 4: the middle estimate sits 2.0-fold (0.30 log units) below what was measured, within the range that was stated.
By their numbers in this assay, from the lowest: compound 3; then compounds 4, 2 and 1 (each within the scatter of the next).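

In this assay, a 60-fold higher number from compound 3 to compound 4 (1.78 log units; beyond the scatter) shows that the low number at this carbonyl carbon does not carry over to 2-(4-chlorophenyl)ethenyl, even though this group also has one six-membered aromatic ring and a similar heavy-atom count. The other two steps, a 1.2-fold lower number from compound 2 to compound 4 (0.07 log units; within the scatter) and a 1.8-fold lower number from compound 1 to compound 4 (0.24 log units; within the scatter), place compound 4 with compound 1 and compound 2, so among these four compounds only the 3-amino-5-nitrophenyl group stands apart. Nothing available accounts for this separation.

The amino and nitro groups occur only together here, so a phenyl ring carrying an amine alone or a nitro group alone would be needed to tell their contributions apart. Going by these compounds, whether the result holds with an amide in place of the ester also remains open.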